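A few compounds are considered here, and "the series" means these few. Any claim that something is new, unique, unknown or untested is made for them only; others in the source may bear on it.

Compound 2 `Cc1c(Cl)cccc1S(=O)(=O)N(C)CCOCC(=O)N(C)Cc1ccc(C2=NCCN2)cc1` gives 6.8 nM in an assay on HEK293 cells for displacement of a labelled ligand from B1 bradykinin receptor (Homo sapiens), read by scintillation counting (a lower number here means a stronger inhibitor, a higher number a weaker inhibitor), the higher of the two numbers measured; compound 1 `Cc1c(Cl)ccc(S(=O)(=O)N(C)CCOCC(=O)N(C)Cc2ccc(C3=NCCN3)cc2)c1Cl` gives 2.1 nM. Among the measured compounds shown here, the one measured step, a 3.2-fold higher number from compound 1 to compound 2 (0.51 log units; beyond the scatter), concerns the same aryl on the sulfonyl sulfur. Compound 3 `CN(Cc1ccc(C2=NCCN2)cc1)C(=O)COCCN(C)S(=O)(=O)c1c(Cl)cccc1Cl` carries 2,6-dichlorophenyl in place of 3-chloro-2-methylphenyl on a sulfonyl sulfur. For the measured compounds named here, no measured step swaps methyl for chlorine on this ring, so the direction is uncertain; a step no larger than a 3.2-fold higher number from compound 1 to compound 2 (0.51 log units; beyond the scatter) in either direction seems plausible. For compound 3 a number near that of compound 2 is expected, the step of a 1.4-fold lower number from compound 2 to compound 3 (0.13 log units; within the scatter) being small. Compound 3 is estimated at 5 nM, with a range of 1.5 nM to 17 nM.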

Compound 3, inhibition constant: 4.2 nM
Compound 3: the middle estimate sits 1.2-fold (0.08 log units) above what was measured; low and high end bracket the measured number.
By their numbers in this assay, from the lowest: compounds 1, 3 and 2 (each within the scatter of the next, the first and the last beyond it).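

On the sulfonyl sulfur, 2,6-dichlorophenyl in place of 3-chloro-2-methylphenyl gives a 1.6-fold lower number from compound 2 to compound 3 (0.21 log units; within the scatter) in this assay and so does not separate these two aryl groups. Against the 2,4-dichloro-3-methylphenyl of compound 1, the same group gives a 2.0-fold higher number from compound 1 to compound 3 (0.30 log units; within the scatter) and also stays within the scatter, so compound 3 cannot be placed apart from either neighbour. No evidence is at hand that would explain these comparisons.

Still open, from the compounds shown here alone, is how a methoxy or trifluoromethyl group on this aryl ring would compare. Going by these compounds, it is also open whether these aryl comparisons would hold with a longer chain on the sulfonamide nitrogen.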